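The source may report more compounds than this note shows. Statements on the series, on what has been measured and on what is new or still open speak of the compounds shown alone.

In a functional assay on RS4-11 cells (Homo sapiens) for inhibition, read by CCK-8 assay, with a stated time of 48 h (a higher number here means a weaker inhibitor, a lower number a stronger inhibitor), compound 1 (`COc1ccc(NC(=O)NCCNS(=O)(=O)c2sccc2-c2ccc(C)cc2Oc2ccc(O)c(O)c2)cc1`) gives 8200 nM and compound 2 (`Nc1ccc(Oc2ccccc2-c2ccc(S(=O)(=O)NCCNC(=O)Nc3cc(C(F)(F)F)cc(C(F)(F)F)c3)s2)cc1`) gives 11900 nM, two values that lie within the scatter of each other. Compound 3 (`O=C(NCCNS(=O)(=O)c1ccc(-c2ccccc2OCc2ccccc2)s1)Nc1cc(C(F)(F)F)cc(C(F)(F)F)c1`) differs from compound 2 at a single place: benzyl in place of 4-aminophenyl on an oxygen on an aromatic ring. For the measured compounds named here, no measured pair shows this change, so no step beyond the scatter is expected in this assay, and no direction is favoured. The expected step is a 1.2-fold lower number from compound 2 to compound 3 (0.08 log units; within the scatter). Compound 3 is estimated at 10000 nM, with an expected range of 3000 nM to 30000 nM.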

Compound 3, half-maximal inhibitory concentration: > 50000 nM
Compound 3 gave a limit, no number (the forecaster's own chance of this, stated with the estimate: 10%); middle value at least 5.0-fold (0.69 log units) from the limit.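

Changing the group on this oxygen matters in this assay: benzyl in place of 4-aminophenyl gives an at least 4.2-fold higher number from compound 2 to compound 3 (0.62 log units; beyond the scatter). The two groups have the same heavy-atom count and each holds one six-membered aromatic ring, but benzyl has no nitrogen, so the response at this position is not a matter of group size alone. The result for compound 3 is a limit, not a number: the limit of > 50000 nM in this assay, at which 1 of the 3 values shown sits.

The compounds shown leave open whether the amine or the extra carbon before the ring accounts for the step. A plain phenyl or a 4-aminobenzyl on the same oxygen would separate the two.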